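The source may report more compounds than this note shows. Statements on the series, on what has been measured and on what is new or still open speak of the compounds shown alone.

In a physicochemical assay for lipophilicity, at pH 7.4 (a higher number here means a more lipophilic compound, a lower number a more polar compound), compound 1 `Cc1cc(COc2ccc(C#N)cc2)nc(-c2ccccn2)n1` gives 2.6, compound 2 `Cc1cc(COc2ccc(F)cc2)nc(-c2ccccn2)n1` gives 3 and compound 3 `CC1(C#N)CN(c2cc(COc3ccc(F)c(F)c3F)nc(-c3ccccn3)n2)C1` gives 3.3. Compound 3 lies within the scatter of compound 2 and beyond the scatter of compound 1, above it. Compound 4 `COC1(COc2cc(COc3ccc(F)c(F)c3F)nc(-c3ccccn3)n2)COC1` carries (3-methoxyoxetan-3-yl)methoxy in place of 3-cyano-3-methylazetidin-1-yl on an aromatic carbon. Going by the values given here, the only measured step, a number 0.40 log units higher from compound 1 to compound 2 (beyond the scatter), is modest and involves a different exchange, so it gives only a rough idea of size. Among the compounds with values here, no measured step covers this exchange. In this assay a small downward step is expected, possibly none beyond the scatter. The estimated step is a number 0.30 log units lower from compound 3 to compound 4 (within the scatter). For compound 4 the estimated value is 3, with an expected range from 2.6 to 3.4.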

Compound 4, distribution coefficient: 3.5
Beside the measured number, compound 4's estimate is 0.50 log units below it; measured number outside the range, above it.
By their numbers in this assay, from the lowest: compound 1; then compounds 2, 3 and 4 (each within the scatter of the next, the first and the last beyond it).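

In this assay, (3-methoxyoxetan-3-yl)methoxy in place of 3-cyano-3-methylazetidin-1-yl gives a number 0.20 log units higher from compound 3 to compound 4 (within the scatter), so this position on the aromatic carbon carries either group with no difference beyond the scatter. The pair holds despite the change in hetero atoms, from nitrogen only to oxygen only, and the loss of the nitrile. No available evidence accounts for this reading. From the compounds shown here alone, whether an amine or a carboxylic acid at this position would give a step beyond the scatter remains open.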